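The source may hold more compounds than are shown below. What is called first, only, known or untested is meant among the compounds shown, and "the series" means these compounds.

Measured so far:
- compound 1 `FC(F)(F)c1ccc(CSc2nc(Nc3cccc(C(F)(F)F)c3)c3ccccc3n2)cc1`: 12900 nM
- compound 2 `Fc1ccc(Nc2nc(SCc3ccc(C(F)(F)F)cc3)nc3ccccc23)cc1`: 7070 nM

Among the measured compounds shown here, in a functional assay on PC-3 cells (Homo sapiens) for cytotoxicity, read by MTT assay, with a stated time of 72 h (a higher number here means a weaker inhibitor, a lower number a stronger inhibitor), compound 2 gives 7070 nM, and compound 1 gives 12900 nM; the only step known, a 1.8-fold lower number from compound 1 to compound 2 (0.26 log units; within the scatter), leaves the two within the scatter of each other. Compound 3 `COc1ccc(Nc2nc(SCc3ccc(C(F)(F)F)cc3)nc3ccccc23)cc1OC` carries the change (3,4-dimethoxyphenyl in place of 4-fluorophenyl on a nitrogen on an aromatic ring). For the measured compounds named here, no measured step swaps a phenyl for a dimethoxyphenyl, so nothing bears directly on it; the one step known was small. Compound 3 is therefore expected near compound 2, with an estimated step of a 1.2-fold lower number from compound 2 to compound 3 (0.07 log units; within the scatter). The estimate for compound 3 in this assay is 6000 nM, between 2000 nM and 20000 nM.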

Compound 3, half-maximal inhibitory concentration: 14100 nM
Compound 3: middle estimate off by 2.4-fold (0.37 log units), on the low side; the measured number falls inside the stated range.
By their numbers in this assay, from the lowest: compounds 2, 1 and 3 (each within the scatter of the next).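

In this assay, 3,4-dimethoxyphenyl on this nitrogen stays within the scatter of both earlier groups (a 2.0-fold higher number from compound 2 to compound 3 (0.30 log units; within the scatter); a 1.1-fold higher number from compound 1 to compound 3 (0.04 log units; within the scatter)). Adding two hydrogen-bond acceptors and exchanging 4-fluorophenyl or 3-(trifluoromethyl)phenyl for this larger group therefore gives no readable change, and these three substituted phenyl groups are not told apart at this position. No evidence is available that bears on this result.

Still open, on these data alone, is whether an unsubstituted phenyl, a carboxylic acid or an amine at this position would move the number beyond the scatter.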